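The source may hold more compounds than are shown below. What is called first, only, known or untested is meant among the compounds shown, and "the series" means these compounds.

Compound 2, `COc1cc(OC)c2sc(-c3ccc(N/C=C\C(=O)c4ccc(OC)c(O)c4)cc3)nc2c1`, and compound 1, `COc1cc(OC)c2sc(-c3ccc(N/C=C\C(=O)c4ccc(OC)c(O)c4)c(C)c3)nc2c1`, share one core, and compound 3, `COc1ccc2nc(-c3ccc(N/C=C\C(=O)c4ccc(OC)c([N+](=O)[O-])c4)cc3)sc2c1`, carries another; the difference between the two cores is not broken down here. In a functional assay on HeLa cells (Homo sapiens) for antiproliferative activity, read by sulforhodamine B assay, with a stated time of 48 h (on this read-out lower numbers stand for stronger inhibition and higher numbers for weaker inhibition), compound 2 gives 12100 nM, compound 1 gives 16100 nM, and compound 3 gives 17600 nM. From compound 2 to compound 1 the change is methyl in place of hydrogen on an aromatic carbon, and it made a 1.3-fold higher number from compound 2 to compound 1 (0.12 log units; within the scatter). Compound 4, `COc1ccc2nc(-c3ccc(N/C=C\C(=O)c4ccc(OC)c([N+](=O)[O-])c4)c(C)c3)sc2c1`, has not yet been measured in this assay. It differs from compound 3 by methyl in place of hydrogen on an aromatic carbon. For the measured compounds named here, this is the same kind of change as the one from compound 2 to compound 1, though not the same: in compound 1 the methyl stands meta to a large group, whereas in compound 4 it stands meta to a 6-methoxy-1,3-benzothiazol-2-yl group. Since the earlier step stayed within the scatter, compound 4 is expected to show a 1.1-fold higher number from compound 3 to compound 4 (0.06 log units; within the scatter) in this assay, resting on compound 3 at 17600 nM and on a 1.3-fold higher number from compound 2 to compound 1 (0.12 log units; within the scatter). Compound 4 is therefore estimated at 20000 nM, between 9000 nM and 45000 nM.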

Compound 4, half-maximal inhibitory concentration: 17600 nM
For compound 4 the middle estimate is 1.1-fold (0.06 log units) above the measured one; measured number inside the range.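

In this assay, methyl in place of hydrogen on an aromatic carbon gives no change at the digits printed from compound 3 to compound 4 (within the scatter). Set beside the earlier step, the change reads alike on the two cores, and the gap between the two steps does not go beyond what such steps scatter: the same change on two cores in this assay, a 1.3-fold higher number (0.12 log units; within the scatter) from compound 2 to compound 1 and no change at the digits printed (within the scatter) from compound 3 to compound 4, 1.3-fold (0.12 log units) apart, within the scatter of two such steps. Within these two pairs, the methyl therefore carries from one core to the other without a change that can be told from the scatter, but two pairs do not show that it would carry the same way to any other core, nor do they show how it would behave in a compound with a much lower number.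

The compounds shown leave open what a group other than methyl would do at this place, such as an ethyl group, an amine or a carboxylic acid. They also leave open whether a methyl on another carbon of the same ring would read alike.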